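Swapping the amide of compound 1 for a pyridinylmethyl ester

The compounds below may be only part of what the source reports. "The series", "measured", "known", "first", "only" and "open" are said of these compounds alone.

Of the compounds shown here, three sharing one core have been measured in an assay on HL-60 cells for agonist activity at vitamin D3 receptor (Homo sapiens), read by microscopy, with a stated time of 96 h; a higher number here means that more compound is needed for the effect, a lower number that less compound is needed. Compound 1, `CCn1c(C(=O)NCCN(C)C)ccc1C(CC)(CC)c1ccc(OCC(=O)C(C)(C)C)c(C)c1`, gives 77 nM. Compound 2, `CCn1c(C(=O)NCCN(C)C)ccc1C(CC)(CC)c1ccc(OCC(O)C(C)(C)C)c(C)c1`, gives 14 nM, and compound 3, `CCn1c(C(=O)N(CCC#N)CCC#N)ccc1C(CC)(CC)c1ccc(OCC(O)C(C)(C)C)c(C)c1`, gives 97 nM. Among these, compound 1 has the second highest number: its value and that of compound 3 lie within the scatter of each other, while compound 2 sits well apart, as the step of a 5.5-fold lower number from compound 1 to compound 2 (0.74 log units; beyond the scatter) shows.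

Compound 4, `CCn1c(C(=O)OCc2ccccn2)ccc1C(CC)(CC)c1ccc(OCC(=O)C(C)(C)C)c(C)c1`, is not yet measured. Relative to compound 1 the change is (pyridin-2-yl)methoxy in place of (2-(dimethylamino)ethyl)amino on a carbonyl carbon.

Within the data shown here, no measured step alters the amide side of the molecule while keeping the rest of compound 1 unchanged. The closest guide is the step of a 6.9-fold higher number from compound 2 to compound 3 (0.84 log units; beyond the scatter), in which a different replacement at the same carbonyl carbon, on a scaffold bearing the 1-hydroxy-2,2-dimethylpropyl group, raised the number. That step suggests changes at this carbonyl carbon are not neutral, but its direction for an ester carrying (pyridin-2-yl)methoxy cannot be read directly from it.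

A moderate rise is expected, so compound 4 is estimated at 200 nM, between 60 nM and 700 nM, which would be a step of a 2.6-fold higher number from compound 1 to compound 4 (0.41 log units; beyond the scatter).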

Compound 4, half-maximal effective concentration: > 50000 nM
Compound 4 ended at the assay's limit; the forecaster's own chance of this, stated with the estimate: 5%; middle value at least 250-fold (2.39 log units) from the limit.
By their numbers in this assay, from the lowest: compound 2; then compounds 1 and 3 (each within the scatter of the next). At a limit, above all of these: compound 4.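

In this assay, compound 4 gives a limit of the assay and not a number: the limit of > 50000 nM in this assay, at which 1 of the 4 values shown sits.

The earlier compounds shown here showed that a replacement on this carbonyl carbon can move the number, with a 6.9-fold higher number from compound 2 to compound 3 (0.84 log units; beyond the scatter), and that step stayed modest on a core bearing the 1-hydroxy-2,2-dimethylpropyl group. With the (tert-butyl)carbonyl group kept, the change from (2-(dimethylamino)ethyl)amino to (pyridin-2-yl)methoxy is far larger, giving an at least 640-fold higher number from compound 1 to compound 4 (2.81 log units; beyond the scatter), so this position can decide whether any effect is seen at all within the range tested.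

This single step swaps several features together: the amide hydrogen leaves, an oxygen takes the place of the nitrogen bound to the carbonyl carbon, and a six-membered aromatic ring enters, so the compounds shown cannot say which of these matters. A (pyridin-2-yl)methylamino group or a 2-(dimethylamino)ethoxy group on the same carbonyl carbon would pull these apart, by testing the aromatic ring on an amide and the ester link with the original dimethylamino chain.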